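A few compounds are considered here, and "the series" means these few. Any claim that something is new, unique, unknown or untested is made for them only; others in the source may bear on it.

Among the three compounds measured in an assay on isolated protein for inhibition of ubiquitin carboxyl-terminal hydrolase 7 (Homo sapiens), with stated times of 30 min and 2 h (a higher number here means a weaker inhibitor, a lower number a stronger inhibitor), compound 2 `Cn1nc2c(=O)n(CC3(O)CCN(Cc4ccc(C5=CCCC5)cc4Cl)CC3)cnc2c1-c1ccc(CN)cc1` gives the lowest number, 76.9 nM. Compound 1 `Cn1nc2c(=O)n(CC3(O)CCN(Cc4ccc(-c5ccco5)cc4Cl)CC3)cnc2c1-c1ccc(C(F)(F)F)cc1` gives 530 nM, and compound 3 `Cn1nc2c(=O)n(CC3(O)CCN(Cc4ccc(-c5ccco5)cc4Cl)CC3)cnc2c1-c1ccc(CNC(=O)C(F)(F)F)cc1` gives 2060 nM. Among the compounds with values here, the only step between compounds that differ in a single place, a 3.9-fold higher number from compound 1 to compound 3 (0.59 log units; beyond the scatter), concerns the group on the other aromatic ring and so does not bear directly on the change ahead. Compound 4 `Cn1nc2c(=O)n(CC3(O)CCN(Cc4ccc(-c5ccc(C(=O)O)o5)cc4Cl)CC3)cnc2c1-c1ccc(CN)cc1` differs from compound 2 in one place: 5-carboxyfuran-2-yl in place of cyclopent-1-en-1-yl on an aromatic carbon. Compound 1 also carries a furan ring at this place, but it differs from compound 2 elsewhere as well, so its number alone cannot settle the matter. Within the data shown here, with no directly comparable step available, a modest weakening is expected, a 2.1-fold higher number from compound 2 to compound 4 (0.32 log units; beyond the scatter). Compound 4 is expected to give 160 nM, in the range 40 nM to 650 nM.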

Compound 4, half-maximal inhibitory concentration: 753 nM
Compound 4: middle estimate off by 4.7-fold (0.67 log units), on the low side, and the stated range ends below it.
By their numbers in this assay, from the lowest: compound 2; then compounds 1 and 4 (each within the scatter of the next); then compound 3.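

At this aromatic carbon, meta to a chloro group, the swap to 5-carboxyfuran-2-yl gives a 9.8-fold higher number from compound 2 to compound 4 (0.99 log units; beyond the scatter) in this assay and so shows that this position responds to what is placed on it. Within the data shown here, the only earlier single-place step concerned the other aromatic ring. No evidence is available to explain this step. Ring type and the carboxylic acid change together here, so which one matters stays open. A plain furan-2-yl on the core of compound 4, or a methyl ester in place of the acid, would separate them.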